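The compounds below may be only part of what the source reports. "The series", "measured", "known", "first", "only" and "open" are said of these compounds alone.

Compound 1 `c1ccc2c(c1)CN[C@@H](CN(CCCCNCC1CCNCC1)[C@H]1CCCc3cccnc31)C2` gives 36.5 nM in a functional assay on cells for antagonist activity at C-X-C chemokine receptor type 4 (Homo sapiens), read by fluorescence and calcium flux, with stated times of 25 min and 90 s (on this read-out higher numbers stand for weaker inhibition and lower numbers for stronger inhibition), and compound 2 `c1ccc2c(c1)CN[C@@H](CN(CCCCNC1CCSCC1)[C@H]1CCCc3cccnc31)C2` gives 54.7 nM. Among the measured compounds shown here, compound 2 sits within the scatter of compound 1, the only other number in hand: the step is a 1.5-fold higher number from compound 1 to compound 2 (0.18 log units; within the scatter). Compound 3 `CC(C)(CCN(C[C@H]1Cc2ccccc2CN1)[C@H]1CCCc2cccnc21)CNC1CCOCC1` differs from compound 2 by a group of 11 heavy atoms (9 carbon, 1 nitrogen, 1 oxygen; one six-membered non-aromatic ring with 1 hetero atom) in place of a group of 9 heavy atoms (7 carbon, 1 nitrogen, 1 sulfur; one six-membered non-aromatic ring with 1 hetero atom), on a saturated chain carbon, two bonds along the chain from an amine nitrogen. For the measured compounds named here, the one measured step, the earlier swap on the amine nitrogen, left the number within the scatter, so no step beyond the scatter is expected here either, a 1.1-fold lower number from compound 2 to compound 3 (0.04 log units; within the scatter). Compound 3 is expected to give 50 nM, with a range of 20 nM to 130 nM.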

Compound 3, half-maximal inhibitory concentration: 36.3 nM
Compound 3: the middle estimate sits 1.4-fold (0.14 log units) above what was measured; low and high end bracket the measured number.
By their numbers in this assay, from the lowest: compounds 3, 1 and 2 (each within the scatter of the next).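

In this assay the group of 11 heavy atoms, on a saturated chain carbon, two bonds along the chain from an amine nitrogen, stays within the scatter of both earlier groups, with a 1.5-fold lower number from compound 2 to compound 3 (0.18 log units; within the scatter) and a 1.0-fold lower number from compound 1 to compound 3 (0.00 log units; within the scatter) as the two steps. The three groups, each with one six-membered non-aromatic ring with 1 hetero atom, cannot be told apart on this read-out. No available data explain this result.

On these data alone, whether a carboxylic acid or a phenyl ring here would give a step beyond the scatter remains open, as does the effect of a longer chain.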